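The compounds below may be only part of what the source reports. "The series", "measured", "known", "first", "only" and "open" are said of these compounds alone.

In an ADME assay on CCRF-HSB-2 cells (Homo sapiens) for cytotoxicity, with a stated time of 7 days (on this read-out higher numbers stand for lower toxicity in this test and lower numbers for higher toxicity in this test), compound 1 `CCOc1nc(N)nc2c1ncn2/C=C1/CC1(CO)CO` gives > 20000 nM, which is a limit of the assay and not a number. Compound 2 `Nc1nc(N2CCCC2)c2ncn(/C=C3/CC3(CO)CO)c2n1` gives > 20000 nM, which is also only a limit. Among the measured compounds shown here, the only measured change is a step that the two limits leave unreadable from compound 1 to compound 2, so it offers no size to build on. All the evidence comes down to a single shared limit: the limit of > 20000 nM in this assay, at which 2 of the 2 values shown sit.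

Compound 3 `CCCCCCCCSc1nc(N)nc2c1ncn2/C=C1/CC1(CO)CO` keeps the shared core and swaps one group: octylsulfanyl in place of pyrrolidin-1-yl on an aromatic carbon. The octylsulfanyl chain has no ring and is longer than either group measured so far, so this is a step into untested ground. With no readable step as a guide, only a modest move toward higher toxicity is expected, and the estimate is loose. The expected change is an at least 1.4-fold lower number from compound 2 to compound 3 (0.15 log units; that floor lies within the scatter). For compound 3 the estimated value is 14000 nM, with an expected range from 3000 nM to 30000 nM.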

Compound 3, half-maximal cytotoxic concentration: 60000 nM
Compound 3: the middle estimate sits 4.3-fold (0.63 log units) below what was measured; the whole stated range lies below it.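

Compound 1 and compound 2 are known only as limits of the assay, so the steps from each of them to compound 3 cannot be read. The compounds shown leave open how far ethoxy, pyrrolidin-1-yl and octylsulfanyl actually differ in this assay.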